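Sulfonyl aryl swap on a quinoline series: fluorophenyl for dichlorophenyl

The source may hold more compounds than are shown below. What is called first, only, known or untested is meant among the compounds shown, and "the series" means these compounds.

Two compounds of the series have a number in an assay on isolated protein for displacement of a labelled ligand from metabotropic glutamate receptor 5 (Homo sapiens), with a stated time of 60 min, tested at 1 uM; on this read-out lower numbers stand for less inhibition and higher numbers for more inhibition at the one concentration tested (going by the name of the read-out). Compound 1 `Cc1ccc2ncc(S(=O)(=O)c3cccc(F)c3)c(N3CCC(C)CC3)c2c1` gives 94% in this assay. Compound 2 `COc1ccc2ncc(S(=O)(=O)c3cc(Cl)cc(Cl)c3)c(N3CCC(C)CC3)c2c1` gives 87% in this assay, the lowest of the two numbers shown, though the value of compound 1 lies only within the scatter of it; the two differ in more than one place, so the pair shows no single step.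

Compound 3 `COc1ccc2ncc(S(=O)(=O)c3cccc(F)c3)c(N3CCC(C)CC3)c2c1` has not yet been measured in this assay. It differs from compound 2 by 3-fluorophenyl in place of 3,5-dichlorophenyl on a sulfonyl sulfur. Within the data shown here, no measured step of this kind is available. Since compound 2 already gives 87% and compound 1 gives 94%, the change is expected to move the number little, if at all, beyond the scatter, with a slight lean upward. The expected step from compound 2 to compound 3 is a number 4 percentage points higher from compound 2 to compound 3 (within the scatter). Compound 3 is thus estimated at 91%, within a range of 80% to 97%.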

Compound 3, a percentage reported as inhibition, at one concentration (the size of the read-out at that concentration, not a potency): 68%
Beside the measured number, compound 3's estimate is 23 percentage points above it; the measured number lies below the stated range.
By their numbers in this assay, from the lowest: compound 3; then compounds 2 and 1 (each within the scatter of the next).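

In this assay the sulfonyl aryl group proves to matter on the methoxy-bearing core: 3-fluorophenyl in place of 3,5-dichlorophenyl on a sulfonyl sulfur gives a number 19 percentage points lower from compound 2 to compound 3 (beyond the scatter), a step beyond the scatter. The aromatic carbon substituent matters as well, as methoxy in place of methyl gives a number 26 percentage points lower from compound 1 to compound 3 (beyond the scatter), so the closeness of compound 1 and compound 2 concealed two separate changes that run in opposite directions along the path through compound 3. No measurement at hand accounts for either step.

The compounds shown leave open whether these two steps are independent, as 3,5-dichlorophenyl appears here only with methoxy on the core and 3-fluorophenyl appears with both methyl and methoxy. Also open, going by these compounds, is how 3-chlorophenyl or a pyridine on a sulfonyl sulfur would read on this core.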